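From Methoxy to Iodo: Estimating Compound 3

The compounds below may be only part of what the source reports. "The series", "measured", "known", "first", "only" and "open" are said of these compounds alone.

Compound 1, `COc1ccccc1Cc1cnc(N)nc1N`: 28800 nM
Compound 2, `Nc1ncc(Cc2ccccc2Br)c(N)n1`: 12300 nM

Within the data shown here, in an assay for inhibition of Dihydrofolate reductase (Gallus gallus) (a lower number here means a stronger inhibitor, a higher number a weaker inhibitor), compound 1 gives 28800 nM, the higher of the two numbers so far. Compound 2 gives 12300 nM. Among the measured compounds shown here, the single measured step, a 2.3-fold lower number from compound 1 to compound 2 (0.37 log units; beyond the scatter), shows that exchanging the methoxy group for a bromo atom lowers the number beyond the scatter, though only modestly.

Compound 3, `Nc1ncc(Cc2ccccc2I)c(N)n1`, differs from compound 1 by iodo in place of methoxy on an aromatic carbon, the change sitting on an aromatic carbon of a six-membered aromatic ring of carbon only. For the measured compounds named here, the only step that bears on this change is the bromo step from compound 1 to compound 2, and iodo is the nearest comparison available. A step of similar size and the same direction is therefore expected, a 3.0-fold lower number from compound 1 to compound 3 (0.48 log units; beyond the scatter), with no basis in the data for anything larger. Compound 3 is accordingly estimated at 9500 nM, with a range from 4000 nM to 25000 nM.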

Compound 3, inhibition constant: 8710 nM
Compound 3: the middle estimate sits 1.1-fold (0.04 log units) above what was measured; the measured number falls inside the stated range.
By their numbers in this assay, from the lowest: compounds 3 and 2 (each within the scatter of the next); then compound 1.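

In this assay, iodo in place of methoxy on this aromatic carbon gives a 3.3-fold lower number from compound 1 to compound 3 (0.52 log units; beyond the scatter) and so confirms, with a second group, the modest change first seen with bromo. Iodo and bromo cannot be separated at this position, since the step between them, a 1.4-fold lower number from compound 2 to compound 3 (0.15 log units; within the scatter), stays within the scatter, so the change from methoxy holds for both groups with no measurable difference between them. No supporting measurement bears on why these replacements lower the number.

The compounds shown leave open whether chloro, fluoro, methyl or an amine at this aromatic carbon would follow bromo and iodo or stay with methoxy. They also leave open whether iodo or bromo would give a step of similar size elsewhere on the six-membered aromatic ring.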